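The compounds below may be only part of what the source reports. "The series", "measured", "known", "first", "only" and "open" are said of these compounds alone.

Measured in an ADME assay on Vero cells (Chlorocebus sabaeus) for cytotoxicity, read by MTT assay, with a stated time of 48 h; a higher number here means that more compound is tolerated, a lower number that less compound is tolerated:
compound 1 `C=C1CC[C@@H]2[C@](C)(CO)[C@H](O)CC[C@@]2(C)[C@@H]1C/C=C1/C(=O)OC[C@H]1OC(=O)CCl` gives 25000 nM
compound 2 `C=C1CC[C@@H]2[C@](C)(CO)[C@H](O)CC[C@@]2(C)[C@@H]1C/C=C1/C(=O)OC[C@H]1OC(=O)CBr` gives 45000 nM

Only these two compounds have been measured, and they lie within the scatter of each other, so compound 2 at 45000 nM does not stand apart from compound 1. Compound 3 `C=C1CC[C@@H]2[C@](C)(CO)[C@H](O)CC[C@@]2(C)[C@@H]1C/C=C1/C(=O)OC[C@H]1OC(=O)CI` keeps the shared core and differs from compound 2 by iodo in place of bromo on a saturated chain carbon bound to a carbonyl carbon. Among the measured compounds shown here, one measured step bears on this change, the swap of chloro for bromo at that same place, and it is a 1.8-fold higher number from compound 1 to compound 2 (0.26 log units; within the scatter). For the measured compounds named here, with only that small step from compound 1 to go on, no step beyond the scatter is expected in this assay, and the direction stays open. The step expected here is a 1.3-fold lower number from compound 2 to compound 3 (0.11 log units; within the scatter). For compound 3 the estimated value is 35000 nM, with an expected range from 14000 nM to 80000 nM.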

Compound 3, concentration lethal to 50% of the cells: 45000 nM
For compound 3 the middle estimate is 1.3-fold (0.11 log units) below the measured one; low and high end bracket the measured number.
By their numbers in this assay, from the lowest: compounds 1, 2 and 3 (each within the scatter of the next).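

In this assay the exchange of bromo for iodo on a saturated chain carbon bound to a carbonyl carbon gives no change at the digits printed from compound 2 to compound 3 (within the scatter), while the exchange of chloro for iodo at that same place gives a 1.8-fold higher number from compound 1 to compound 3 (0.26 log units; within the scatter). The earlier pair covered only chloro and bromo, and with iodo added, all three compounds stand within the scatter of one another, so this series of halogens gives no readable trend at this position. Nothing at hand explains this result.

The compounds shown carry only these three halogens at this place, so they do not tell how an amine, a hydroxyl group or a longer chain there would read. Going by these compounds, whether a halogen is needed at all, as against plain acetyl with no halogen, also stays open.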